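The compounds below may be only part of what the source reports. "The series", "measured", "known", "first", "only" and "open" are said of these compounds alone.

The series shares a core carrying two benzyloxy groups, and it is followed in a functional assay on HepG2 cells (Homo sapiens) for inhibition, read by MTT assay, with a stated time of 72 h; a lower number here means a stronger inhibitor, a higher number a weaker inhibitor. Compound 1 `O=C1O[C@H]([C@@H](O)Cn2ccc(NC(=O)c3ccccc3)nc2=O)C(OCc2ccccc2)=C1OCc1ccccc1` gives 62200 nM there. Compound 3 `O=C1O/C(=C\Cn2ccc(NC(=O)c3ccccc3)nc2=O)C(OCc2ccccc2)=C1OCc1ccccc1` gives 1980 nM in this assay. Compound 2 `NC1(CCn2ccc(=O)[nH]c2=O)OC(=O)C(OCc2ccccc2)=C1OCc1ccccc1` is reported in this assay only as a limit, > 100000 nM, and not as a number; it sits at the limit of > 100000 nM in this assay, at which 1 of the 3 values shown sits. On the numbers shown, compound 2 therefore stands at the weak end, with the other two values lying below its limit.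

Compound 4 `NC1(CCn2c(=O)[nH]c(=O)[nH]c2=O)OC(=O)C(OCc2ccccc2)=C1OCc1ccccc1` is not yet measured in this assay. It differs from compound 2 by a group of 9 heavy atoms (3 carbon, 3 nitrogen, 3 oxygen; one six-membered aromatic ring with 3 hetero atoms) in place of a group of 8 heavy atoms (4 carbon, 2 nitrogen, 2 oxygen; one six-membered aromatic ring with 2 hetero atoms), on a saturated chain carbon, two bonds along the chain from a saturated ring carbon. For the measured compounds named here, no measured pair in this set shows the effect of such an exchange, so the expectation rests on compound 2 alone. Since compound 2 already reaches only a limit, the exchange is expected to bring no step beyond the usual scatter, and a further limit is the most likely outcome. The expected step from compound 2 to compound 4 is a step that the limit leaves unreadable from compound 2 to compound 4. In this assay compound 4 is estimated at 150000 nM, within a range from 50000 nM to 500000 nM, with a limit rather than a number likely to be reported.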

Compound 4, half-maximal inhibitory concentration: > 100000 nM
Compound 4: no number, only a limit (the forecaster's own chance of this, stated with the estimate: 75%); the middle value lies beyond the limit too.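

Like compound 2, compound 4 is reported in this assay only as a limit, > 100000 nM. The step between these two compounds therefore cannot be read: the limit of > 100000 nM in this assay, at which 2 of the 4 values shown sit. The compounds shown leave open how far either compound lies beyond its limit, and whether exchanging the one ring group for the other changes inhibition at all.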